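Bromo to fluoro swap on the shared core: notes

The source may hold more compounds than are shown below. What is called first, only, known or untested is meant among the compounds shown, and "the series" means these compounds.

Measured in a functional assay on KG-1 cells (Homo sapiens) for cytotoxicity, read by luminescence and CellTiter-Glo, with a stated time of 3 days; on this read-out higher numbers stand for weaker inhibition and lower numbers for stronger inhibition:
compound 1 `O=C(Nc1ccc(C(F)(F)F)cc1)c1cc(F)ccc1O`: 1700 nM
compound 2 `O=C(Nc1ccc(C(F)(F)F)cc1)c1ccc(Br)cc1O`: 340 nM
compound 3 `O=C(Nc1ccc(C(F)(F)F)cc1)c1cc(Br)ccc1O`: 610 nM

Compound 2 has the lowest number of the three. Compound 3 comes nearest to it, and the two lie within the usual scatter, so no order is claimed between them. Compound 1 stands furthest from compound 2, beyond the scatter. Compound 2 and compound 3 hold the same atoms joined differently; the difference between the two cores is not broken down here.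

One change is measured in this assay: fluoro in place of bromo on an aromatic carbon gave a 2.8-fold higher number from compound 3 to compound 1 (0.45 log units; beyond the scatter).

Compound 4 `O=C(Nc1ccc(C(F)(F)F)cc1)c1ccc(F)cc1O` is not yet measured. It differs from compound 2 by fluoro in place of bromo on an aromatic carbon. This is the same kind of change as from compound 3 to compound 1, not the same: in compound 1 the entering fluoro sits meta to a large group and para to a hydroxy group, in compound 4 meta to a hydroxy group and para to a large group. Among the compounds shown the change occurs twice in all.

From compound 2 to compound 4 a step of a 2.8-fold higher number from compound 2 to compound 4 (0.45 log units; beyond the scatter) in this assay is expected, placed beside the measured 2.8-fold higher number from compound 3 to compound 1 (0.45 log units; beyond the scatter); this rests on compound 2 at 340 nM and on that single measured step, with no second instance to show whether the different surroundings alter its size. For compound 4 the estimate is 950 nM, expected to fall between 420 nM and 2400 nM.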

Compound 4, half-maximal inhibitory concentration: 740 nM
Compound 4: middle estimate off by 1.3-fold (0.11 log units), on the high side; measured number inside the range.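

In this assay fluoro in place of bromo on an aromatic carbon gave a 2.2-fold higher number from compound 2 to compound 4 (0.34 log units; beyond the scatter) with the entering fluoro meta to a hydroxy group and para to a large group, so the step keeps its direction on the second core. Only these two pairs stand behind the result, so it gives no general rule for other cores and does not show why the change raises the number on either one. Within these two pairs the change carries from one core to the other with no measurable difference in size: the same change on two cores in this assay, a 2.8-fold higher number (0.45 log units; beyond the scatter) from compound 3 to compound 1 and a 2.2-fold higher number (0.34 log units; beyond the scatter) from compound 2 to compound 4, 1.3-fold (0.11 log units) apart, within the scatter of two such steps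

The compounds shown carry only bromo or fluoro at the changing carbon, while the hydroxy group and the trifluoromethyl group stay the same throughout. On these data alone, it remains open whether a step of this size would hold for chloro or a nitrile on that carbon, or on a core with an amine in place of the hydroxy group.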